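This account rests on a few compounds, and the source may have more. Where it says the series, first, only, none or still open, it means among the compounds named here.

Compound 1 `CCOC(=O)c1c(C)nc(-c2cccc(C#N)c2)n1OC` is the starting point. In a functional assay on a cell-free system (plasma, Oryctolagus cuniculus) for inhibition, with stated times of 5 min, 1 min and 6 min (a lower number here means a stronger inhibitor, a higher number a weaker inhibitor), compound 1 gives 9130 nM, the highest of the two plain numbers shown. Compound 3 `CCOC(=O)c1c(C)nc(-c2cccc(C#N)c2)n1OCc1ccc(Cl)cc1` gives 6830 nM in this assay, and the step of a 1.3-fold lower number from compound 1 to compound 3 (0.13 log units; within the scatter) sits within the scatter. Compound 2 `CCOC(=O)c1c(C)nc(-c2cccc(C#N)c2)n1OCCC(=O)O` reaches only a limit in this assay, > 30000 nM (the limit of > 30000 nM in this assay, at which 1 of the 3 values shown sits). The step of an at least 3.2-fold higher number from compound 1 to compound 2 (0.51 log units; beyond the scatter) and the step of an at least 4.3-fold lower number from compound 2 to compound 3 (0.64 log units; beyond the scatter) show that the carboxymethyl group sets a weaker result. Compound 4 `CCOC(=O)c1c(C)nc(-c2cccc(C#N)c2)n1OCc1ccc(OC)cc1` differs from compound 1 by 4-methoxyphenyl in place of hydrogen on a saturated chain carbon bound to an oxygen on an aromatic ring. The step most like it, compound 1 to compound 3, placed another six-membered aromatic ring at the same carbon without moving beyond the scatter, so the step of a 1.3-fold lower number from compound 1 to compound 4 (0.12 log units; within the scatter) is expected to stay within the scatter as well. Compound 4 is therefore estimated at 7000 nM, between 3000 nM and 17000 nM.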

Compound 4, half-maximal inhibitory concentration: 6830 nM
Compound 4: the middle estimate sits 1.0-fold (0.01 log units) above what was measured, and the stated range covers the measured number.
By their numbers in this assay, from the lowest: compounds 3, 4 and 1 (each within the scatter of the next). At a limit, above all of these: compound 2.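

Methoxy in place of chloro on an aromatic carbon gives no change at the digits printed from compound 3 to compound 4 (within the scatter), so in this assay these two substituents on the phenyl ring read alike. Placing 4-methoxyphenyl on the saturated chain carbon in place of hydrogen gives a 1.3-fold lower number from compound 1 to compound 4 (0.13 log units; within the scatter), so a second aryl group here also stays within the scatter. Placing it there in place of carboxymethyl gives an at least 4.3-fold lower number from compound 2 to compound 4 (0.64 log units; beyond the scatter), a step that rests on a limit: the limit of > 30000 nM in this assay, at which 1 of the 4 values shown sits.

Still open, from the compounds shown here alone, is how an amine or a longer plain alkyl chain on this carbon would read. Also open, going by these compounds, is whether any group here can move the number beyond the scatter of compound 1 towards a stronger inhibitor.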